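Compound 1 to compound 4: carbonyl substituent swap

The source may hold more compounds than are shown below. What is called first, only, known or untested is meant among the compounds shown, and "the series" means these compounds.

Measured in a functional assay on ID8 cells (Mus musculus) for antiproliferative activity; a lower number here means a stronger inhibitor, a higher number a weaker inhibitor:
- compound 1 `O=C(Nc1ccc(O)c2c(=O)cc(-c3ccccc3Cl)oc12)c1ccc(Cl)c(Cl)c1`: 13000 nM
- compound 2 `CC(C)C[C@@H](NC(=O)OC(C)(C)C)C(=O)Nc1ccc(O)c2c(=O)cc(-c3ccccc3Cl)oc12`: 17000 nM
- compound 3 `CSCC[C@@H](NC(=O)OC(C)(C)C)C(=O)Nc1ccc(O)c2c(=O)cc(-c3ccccc3Cl)oc12`: 13000 nM

Compound 1 stands level with compound 3, and compound 2 lies within the scatter of both. Compound 4 `CCC(C)OC(=O)Nc1ccc(O)c2c(=O)cc(-c3ccccc3Cl)oc12` is not yet measured. It carries sec-butoxy in place of 3,4-dichlorophenyl on a carbonyl carbon.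

For the measured compounds named here, no measured step covers this exchange. The only one available is a 1.3-fold lower number from compound 2 to compound 3 (0.12 log units; within the scatter), at a different place, so it bears only indirectly. Compounds 2 and 3 also differ from compound 1 on that carbonyl carbon, yet their values show no separation from it. The expected change is therefore none beyond the scatter, with an estimated step of a 1.2-fold higher number from compound 1 to compound 4 (0.06 log units; within the scatter). Compound 4 is expected at 15000 nM, within an estimated range of 6000 nM to 35000 nM.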

Compound 4, half-maximal inhibitory concentration: 18000 nM
Beside the measured number, compound 4's estimate is 1.2-fold (0.08 log units) below it, within the range that was stated.
By their numbers in this assay, from the lowest: compounds 1, 3, 2 and 4 (each within the scatter of the next).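

In this assay, for the compounds shown here, sec-butoxy in place of 3,4-dichlorophenyl on the carbonyl carbon gives a 1.4-fold higher number from compound 1 to compound 4 (0.14 log units; within the scatter), the first direct reading of a change at this position. An aromatic ring of carbon only and a ringless group with one hydrogen-bond acceptor thus read alike here, with no separation beyond the scatter. No measured evidence on hand bears on this result.

The compounds shown do not reveal any group at this position that moves the number beyond the scatter. As far as these compounds go, a longer chain in place of sec-butoxy, or a carboxylic acid or an amine on this carbonyl carbon, remains open.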